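Bromo in place of heptyl: notes on compound 3

A few compounds are considered here, and "the series" means these few. Any claim that something is new, unique, unknown or untested is made for them only; others in the source may bear on it.

The series shares one core, seen in compound 1 `CCCCCCCc1ccc(NS(=O)(=O)c2ccc(N3CCNC3=O)cc2)cc1` and in compound 2 `COc1ccc(NS(=O)(=O)c2ccc(N3CCNC3=O)cc2)cc1OC`. In a functional assay on M21 cells (Homo sapiens) for antiproliferative activity, read by sulforhodamine B assay, with a stated time of 48 h (a lower number here means a stronger inhibitor, a higher number a weaker inhibitor), compound 1 gives only a limit, > 1000 nM. In this assay compound 2 gives 340 nM. Within the data shown here, no measured pair differs in a single place, so no measured step is at hand; compound 1 stands at the limit of > 1000 nM in this assay, at which 1 of the 2 values shown sits, and of compound 1 and compound 2 the two values show only that compound 2 has a number where compound 1 has none.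

Compound 3 `O=C1NCCN1c1ccc(S(=O)(=O)Nc2ccc(Br)cc2)cc1`, not yet measured, differs from compound 1 by bromo in place of heptyl on an aromatic carbon. Since compound 1 sits at the limit of > 1000 nM in this assay, at which 1 of the 2 values shown sits, the size of the step cannot be read from the measured values and is expected to be moderate, towards a stronger inhibitor. The expected step is an at least 2.0-fold lower number from compound 1 to compound 3 (0.30 log units; that floor lies within the scatter). Compound 3 is expected to give about 500 nM in this assay, with a range from 150 nM to 2000 nM.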

Compound 3, half-maximal inhibitory concentration: 130 nM
For compound 3 the middle estimate is 3.8-fold (0.59 log units) above the measured one, and the stated range ends above it.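

In this assay this aromatic carbon, para to a large group, now has its first readable change: bromo in place of heptyl gives an at least 7.6-fold lower number from compound 1 to compound 3 (0.88 log units; beyond the scatter). With heptyl, 7 heavy atoms, replaced by bromo, 1 heavy atom, the position evidently does not need a long chain for the series to give a number in this assay. The step is only a floor and its full size cannot be read, since compound 1 stands at a limit: the limit of > 1000 nM in this assay, at which 1 of the 3 values shown sits.

As far as these compounds go, what stays open is whether the change in compound 3 owes more to the loss of heptyl or to the presence of bromo. A shorter chain such as ethyl, an amine or a carboxylic acid on this carbon would help separate the two readings.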